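A few compounds are considered here, and "the series" means these few. Any claim that something is new, unique, unknown or untested is made for them only; others in the source may bear on it.

Compound 1 `CCn1cc(-c2nc3ccccc3[nH]2)c(=O)c2cc(F)c(N3CCNCC3)nc21` gives 4100 nM 
Compound 2 `CCn1cc(-c2nc3ccccc3[nH]2)c(=O)c2cc(F)c(N3CCNC(C)C3)c(F)c21` gives 30200 nM 
Compound 3 `CCn1cc(-c2nc3ccccc3o2)c(=O)c2cc(F)c(N3CCNC(C)C3)c(F)c21` gives 5700 nM 
Compound 4 `CCn1cc(-c2nc3ccccc3o2)c(=O)c2cc(F)c(N3CCNCC3)nc21` is not yet measured

In a functional assay on Bel-7402 cells (Homo sapiens) for cytotoxicity, read by MTT assay, with a stated time of 48 h (a lower number here means a stronger inhibitor, a higher number a weaker inhibitor), compound 1 at 4100 nM stands within the scatter of compound 3, and both numbers lie lower than that of compound 2. Compound 4 differs from compound 1 by 1,3-benzoxazol-2-yl in place of 1H-benzimidazol-2-yl on an aromatic carbon and carries 1,3-benzoxazol-2-yl in place of 1H-benzimidazol-2-yl on an aromatic carbon. Among the measured compounds shown here, the one measured step with this change is a 5.3-fold lower number from compound 2 to compound 3 (0.72 log units; beyond the scatter) on a core other than that of compound 1 and so bears only in part. A lower number is therefore expected in this assay but by less than that step. The estimated step of a 2.7-fold lower number from compound 1 to compound 4 (0.44 log units; beyond the scatter) is the expectation here. Compound 4 is estimated at 1500 nM with a range from 500 nM to 4500 nM expected.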

Compound 4, half-maximal inhibitory concentration: 16800 nM
The estimate for compound 4 lay 11-fold (1.05 log units) below the measured number, and the stated range ends below it.
By their numbers in this assay, from the lowest: compounds 1 and 3 (each within the scatter of the next); then compounds 4 and 2 (each within the scatter of the next).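

In this assay, 1,3-benzoxazol-2-yl in place of 1H-benzimidazol-2-yl on this aromatic carbon gives a 4.1-fold higher number from compound 1 to compound 4 (0.61 log units; beyond the scatter), so the change no longer reads as a gain in the lower direction. Its direction at this position depends on the core that carries it, and the two steps run opposite ways: the same change on two cores in this assay, a 5.3-fold lower number (0.72 log units; beyond the scatter) from compound 2 to compound 3 and a 4.1-fold higher number (0.61 log units; beyond the scatter) from compound 1 to compound 4, 22-fold (1.34 log units) apart, beyond the scatter of two such steps.

The two cores differ in more than one place, and the compounds shown leave open which of those differences turns the step around. They also leave open how a carboxylic acid or a 1,3-benzothiazol-2-yl group would read on this same aromatic carbon.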